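From 3-(trifluoromethyl)phenyl to 2-(trifluoromethyl)phenyl on the sulfonyl sulfur

This account rests on a few compounds, and the source may have more. Where it says the series, first, only, none or still open, it means among the compounds named here.

In a functional assay on VCaP cells (Homo sapiens) for antiproliferative activity, read by propidium iodide staining, with a stated time of 96 h (on this read-out higher numbers stand for weaker inhibition and lower numbers for stronger inhibition), compound 1 `CC(O)(CS(=O)(=O)c1ccc(F)cc1)C(=O)Nc1ccc(S(F)(F)(F)(F)F)cc1` gives 34200 nM as its result, and compound 2 `CC(O)(CS(=O)(=O)c1cccc(C(F)(F)F)c1)C(=O)Nc1ccc(S(F)(F)(F)(F)F)cc1` gives 32000 nM on the same measure. Within the data shown here, compound 2 therefore stands level with compound 1, the only other compound measured so far. Among the measured compounds shown here, the one measured step is a 1.1-fold lower number from compound 1 to compound 2 (0.03 log units; within the scatter) and it exchanges one aryl group on the sulfonyl sulfur for another.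

Compound 3 `CC(O)(CS(=O)(=O)c1ccccc1C(F)(F)F)C(=O)Nc1ccc(S(F)(F)(F)(F)F)cc1` has not yet been measured in this assay by this account. It carries 2-(trifluoromethyl)phenyl in place of 3-(trifluoromethyl)phenyl on a sulfonyl sulfur, whose other neighbour is a saturated chain carbon 2-(trifluoromethyl)phenyl in place of 3-(trifluoromethyl)phenyl on a sulfonyl sulfur and the two structures hold the same atoms, joined differently. For the measured compounds named here, no measured pair changes only the place of the trifluoromethyl group, so the evidence is indirect. Going by the values given here, with a 1.1-fold lower number from compound 1 to compound 2 (0.03 log units; within the scatter) as the only guide, no step beyond the scatter is expected in either direction, and the estimated change is a 1.1-fold lower number from compound 2 to compound 3 (0.03 log units; within the scatter) in this reading. For compound 3 the estimated value is 30000 nM within an expected range of 14000 nM to 60000 nM in this assay.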

Compound 3, half-maximal inhibitory concentration: 23800 nM
Compound 3: middle estimate off by 1.3-fold (0.10 log units), on the high side; measured number inside the range.
By their numbers in this assay, from the lowest: compounds 3, 2 and 1 (each within the scatter of the next).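

Moving the trifluoromethyl group on the aromatic ring, with 2-(trifluoromethyl)phenyl in place of 3-(trifluoromethyl)phenyl on the sulfonyl sulfur, gives a 1.3-fold lower number from compound 2 to compound 3 (0.13 log units; within the scatter) in this assay and so tests the place of this group on its own for the first time, with a step that stays within the scatter. Against the 4-fluorophenyl group of compound 1, the same 2-(trifluoromethyl)phenyl group gives a 1.4-fold lower number from compound 1 to compound 3 (0.16 log units; within the scatter) and this step is also within the scatter, so the three aryl groups on this sulfur cannot be ranked in this assay. Nothing available bears on why these aryl exchanges leave the read-out within the scatter.

All three compounds keep the rest of the shared core unchanged, so they do not show whether a change elsewhere in the core would give a larger step than any exchange at this sulfonyl sulfur. They also leave open whether an amine or a carboxylic acid on the aromatic ring, or a plain methyl group on the sulfur in place of the aryl group, would give a step beyond the scatter.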